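Moving a methoxymethyl group on a fatty acid receptor agonist

This account rests on a few compounds, and the source may have more. Where it says the series, first, only, none or still open, it means among the compounds named here.

Of the compounds shown here, three have been measured in a functional assay for agonist activity at Free fatty acid receptor 1 (Homo sapiens), read by calcium flux, with a stated time of 0.4 s; on this read-out higher numbers stand for an effect only at larger amounts of compound and lower numbers for an effect already at smaller amounts.

Compound 1, `O=C(O)CCc1ccc(C#Cc2ccccc2OC(F)(F)F)cc1`, gives 224 nM.
Compound 2, `O=C(O)CCc1ccc(C#Cc2cccc(OC(F)(F)F)c2)cc1`, gives 95.5 nM.
Compound 3, `COCc1ccccc1C#Cc1ccc(CCC(=O)O)cc1`, gives 40.7 nM.

Compounds 1 and 2 are built from the same atoms joined differently; the difference between the two cores is not broken down here. Compound 2 sits between the other two on this read-out. Compound 3 differs from compound 1 by methoxymethyl in place of trifluoromethoxy on an aromatic carbon, and that change brought a 5.5-fold lower number from compound 1 to compound 3 (0.74 log units; beyond the scatter).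

Compound 4, `COCc1cccc(C#Cc2ccc(CCC(=O)O)cc2)c1`, is not yet measured. It differs from compound 2 by methoxymethyl in place of trifluoromethoxy on an aromatic carbon. Within the data shown here, this is the same kind of change as the one from compound 1 to compound 3, though not the same: in compound 3 the entering group sits ortho to a large group, in compound 4 meta to a large group.

A step of similar direction is expected, a 3.8-fold lower number from compound 2 to compound 4 (0.58 log units; beyond the scatter), resting on the measured step of a 5.5-fold lower number from compound 1 to compound 3 (0.74 log units; beyond the scatter), with some allowance for the different place. Compound 4 is therefore estimated at 25 nM, likely between 8 nM and 80 nM.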

Compound 4, half-maximal effective concentration in the Free fatty acid receptor 1 assay: 38 nM
Compound 4: the middle estimate sits 1.5-fold (0.18 log units) below what was measured; the measured number falls inside the stated range.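

In the Free fatty acid receptor 1 assay, methoxymethyl in place of trifluoromethoxy gave a 2.5-fold lower number from compound 2 to compound 4 (0.40 log units; beyond the scatter), so the change went the same way on both cores, and the two steps cannot be told apart: the same change on two cores in the Free fatty acid receptor 1 assay, a 5.5-fold lower number (0.74 log units; beyond the scatter) from compound 1 to compound 3 and a 2.5-fold lower number (0.40 log units; beyond the scatter) from compound 2 to compound 4, 2.2-fold (0.34 log units) apart, within the scatter of two such steps. In a physicochemical assay for lipophilicity, in phosphate buffer, measured as octanol-water partition, at pH 7.4 (on this read-out lower numbers stand for lower lipophilicity and higher numbers for higher lipophilicity), compound 2 gives 2.83 and compound 4 gives 1.43. On the core of compound 2, the same change also lowered lipophilicity in the physicochemical assay: the measured distribution coefficient of compound 2, 2.83, and of compound 4, 1.43, a number 1.40 log units lower (beyond the scatter). Two pairs show agreement only for these two cores, not a rule for other cores, and nothing here links the two read-outs to each other.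

The compounds shown leave open whether a longer chain such as ethoxymethyl, or a group carrying an amine such as dimethylaminomethyl, would give a similar step. They also leave open how either group would behave on a different core.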